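From Thiophen-2-yl to Pyridin-4-yl on the Shared Core

The compounds below may be only part of what the source reports. "The series", "measured", "known", "first", "only" and "open" are said of these compounds alone.

Compound 1 `COc1cccc(Nc2nccc(-c3cccs3)n2)c1` gives 900 nM in a functional assay for inhibition, with Homo sapiens as the target (on this read-out higher numbers stand for weaker inhibition and lower numbers for stronger inhibition), the lowest of the three numbers measured. Compound 2 `CN(C)c1cccc(Nc2nccc(-c3cccs3)n2)c1` gives 2400 nM and compound 3 `c1ccc(Nc2nccc(-c3cccs3)n2)cc1` gives 31700 nM; the steps of a 2.7-fold higher number from compound 1 to compound 2 (0.43 log units; beyond the scatter) and a 35-fold higher number from compound 1 to compound 3 (1.55 log units; beyond the scatter) are both beyond the scatter, as is a 13-fold higher number from compound 2 to compound 3 (1.12 log units; beyond the scatter). Compound 4 `COc1cccc(Nc2nccc(-c3ccncc3)n2)c1` differs from compound 1 in one place: pyridin-4-yl in place of thiophen-2-yl on an aromatic carbon. All three measured steps change the methoxy or dimethylamino group and leave the thiophen-2-yl untouched, so none of them bears on this exchange of one aromatic ring for another. For the measured compounds named here, with no guiding step, a change within or modestly beyond the scatter in either direction is plausible. Compound 4 is estimated at 1500 nM, within a range of 300 nM to 8000 nM, so the expected step is a 1.7-fold higher number from compound 1 to compound 4 (0.22 log units; within the scatter).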

Compound 4, half-maximal inhibitory concentration: 400 nM
Estimate against measurement, compound 4: 3.8-fold (0.57 log units) above, and the stated range covers the measured number.
By their numbers in this assay, from the lowest: compound 4; then compound 1; then compound 2; then compound 3.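

In this assay, the position opposite the ring nitrogen accepts a different aromatic ring without loss of inhibition: pyridin-4-yl in place of thiophen-2-yl gives a 2.3-fold lower number from compound 1 to compound 4 (0.35 log units; beyond the scatter). For the compounds shown here, the earlier steps changed only the methoxy or dimethylamino group, so this is the first sign that this second place on the shared core also moves the number. Nothing shown explains why the number falls.

Still open, on these data alone, is whether pyridin-3-yl or furan-2-yl would serve as well at this position. Also open, as far as these compounds go, is whether pyridin-4-yl gives a similar step when paired with dimethylamino instead of methoxy.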